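Acetyl in place of an enol ether on the anilino ring

The source may report more compounds than this note shows. Statements on the series, on what has been measured and on what is new or still open speak of the compounds shown alone.

Measured compounds in an assay on FRT-Jurkat cells for inhibition of nuclear factor NF-kappa-B complex (Homo sapiens), read by flow cytometry, with a stated time of 24 h, tested at 10 uM; on this read-out higher numbers stand for more inhibition at the one concentration tested (going by the name of the read-out) and lower numbers for less inhibition:
compound 1, `CN(c1ccccc1)c1ccc2c(c1)C(=O)N(C1CCC(=O)NC1=O)C2=O`: -2%
compound 2, `C=C(OCC)c1ccc(Nc2cccc3c2C(=O)N(C2CCC(=O)NC2=O)C3=O)cc1`: 10%
compound 3, `COc1ccc(Nc2ccc3c(c2)C(=O)N(C2CCC(=O)NC2=O)C3=O)cc1`: 29%

Compound 2 gives 10% in this assay, the second highest of the three numbers, beyond the scatter of compound 1 and of compound 3. Compound 4, `CC(=O)c1ccc(Nc2cccc3c2C(=O)N(C2CCC(=O)NC2=O)C3=O)cc1`, differs from compound 2 by acetyl in place of 1-ethoxyethenyl on an aromatic carbon. For the measured compounds named here, no measured step matches this change: the one step on record, a number 31 percentage points higher from compound 1 to compound 3 (beyond the scatter), alters the amine on a different part of the core and does not bear on it. With the two groups alike in their counted atoms and acceptors, no step beyond the scatter is expected. Compound 4 is therefore estimated at 14%, between -4% and 32%, an expected step of a number 4 percentage points higher from compound 2 to compound 4 (within the scatter).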

Compound 4, a percentage reported as inhibition, at one concentration (the size of the read-out at that concentration, not a potency): 2%
Estimate against measurement, compound 4: 12 percentage points above; the range from low to high includes it.
By their numbers in this assay, from the lowest: compounds 1, 4 and 2 (each within the scatter of the next, the first and the last beyond it); then compound 3.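

On this assay, acetyl in place of 1-ethoxyethenyl, on an aromatic carbon para to a large group, gives a number 8 percentage points lower from compound 2 to compound 4 (within the scatter). For the compounds shown here, this is the first comparison at this position, and the read-out does not tell the two groups apart, although acetyl is the smaller of them. No measurement available bears on why the two groups read alike.

As far as these compounds go, it remains open whether an amine or a carboxylic acid on this same carbon would shift the number beyond the scatter. Whether a longer chain ending in a ketone would do so is equally unsettled.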